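Replacing Chloro with (4-Chlorophenyl)amino on the Shared Core

The source may report more compounds than this note shows. Statements on the series, on what has been measured and on what is new or still open speak of the compounds shown alone.

Compound 2, `N#Cc1c(Cl)nc(SCC(=O)Nn2c(COc3ccc(Cl)cc3Cl)nc3ccccc3c2=O)nc1-c1ccc(O)cc1`, stands highest of the two numbers measured in a functional assay on the whole organism (strain albino) for inhibition, with Rattus norvegicus as the target, read by paw edema, with stated times of 1 h and 3 h, at a dose of 100 mg/kg by the oral route; on this read-out lower numbers stand for a weaker effect and higher numbers for a stronger effect at the one dose given; in that assay compound 2 gives 73.7%. Its nearest neighbour is compound 1, `N#Cc1c(Cl)nc(SCC(=O)Nn2c(COc3ccc(Cl)cc3Cl)nc3ccccc3c2=O)nc1-c1ccccc1`, which in this assay gives 68.4%. Within the data shown here, the one measured step between them, a number 5.3 percentage points higher from compound 1 to compound 2 (within the scatter), lies within the scatter, so the two compounds cannot be told apart on these numbers.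

Compound 3, `N#Cc1c(Nc2ccc(Cl)cc2)nc(SCC(=O)Nn2c(COc3ccc(Cl)cc3Cl)nc3ccccc3c2=O)nc1-c1ccc(O)cc1`, differs from compound 2 in a single place: (4-chlorophenyl)amino in place of chloro on an aromatic carbon. Among the measured compounds shown here, no measured step bears directly on this exchange. For the measured compounds named here, the only step on record, a number 5.3 percentage points higher from compound 1 to compound 2 (within the scatter), concerns hydroxy in place of hydrogen and was itself within the scatter, so it offers no direction for a change of chloro to (4-chlorophenyl)amino. With nothing to rest on beyond the value of compound 2, the expectation is for no step beyond the scatter, but with a wide range to reflect the uncertainty. The step expected is a number 3.7 percentage points lower from compound 2 to compound 3 (within the scatter). Compound 3 is accordingly estimated to give 70% in this assay, with a range from 50% to 85%.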

Compound 3, a percentage reported as inhibition, in the whole organism at one dose (the size of the read-out at that dose, not a potency): 79%
Compound 3: middle estimate off by 9 percentage points, on the low side; measured number inside the range.
By their numbers in this assay, from the lowest: compounds 1, 2 and 3 (each within the scatter of the next, the first and the last beyond it).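

In this assay, (4-chlorophenyl)amino in place of chloro on this aromatic carbon, ortho to a cyano group and next to the ring nitrogen, gives a number 5.3 percentage points higher from compound 2 to compound 3 (within the scatter), so compound 2 and compound 3 cannot be told apart on these numbers. Among these compounds, this is the first look at this position, and it shows that the single chlorine can give way to a far larger group, one that brings a six-membered aromatic ring of carbon only and a hydrogen-bond donor, with no loss of effect beyond the scatter at the one dose given. Nothing on hand explains why the read-out tolerates this exchange.

From the compounds shown here alone, what a plain amino group, a morpholine ring or a phenylamino group without the chlorine would give at this carbon stays open, and with it whether the chlorine on the entering ring plays any part. Going by these compounds, the read-out at one dose is also not a potency, so whether compound 2 and compound 3 would separate at other doses remains open as well.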